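Isopropyl for methyl on the group at the indole-free nitrogen

A few compounds are considered here, and "the series" means these few. Any claim that something is new, unique, unknown or untested is made for them only; others in the source may bear on it.

Compound 1 `CCCCCCCn1ccc2cc(/C(C)=C/C(=O)Nc3ccccc3OCCCC(=O)O)ccc21`: 120 nM
Compound 2 `C/C(=C\C(=O)Nc1ccccc1OCCCC(=O)O)c1ccc2c(ccn2C(C)c2ccccc2)c1`: 19 nM

Going by the values given here, in an assay on Prostate gland for inhibition of steroid 5-alpha-reductase (Rattus norvegicus) (a lower number here means a stronger inhibitor, a higher number a weaker inhibitor), compound 2 holds the lower of the two numbers; the only measured step, a 6.3-fold lower number from compound 1 to compound 2 (0.80 log units; beyond the scatter), separates them. Compound 3 `C/C(=C\C(=O)Nc1ccccc1OCCCC(=O)O)c1ccc2c(ccn2C(c2ccccc2)C(C)C)c1` differs from compound 2 by isopropyl in place of methyl on a saturated chain carbon bound to an aromatic carbon and an aromatic nitrogen. Among the compounds with values here, no measured step covers this exact change; the one step in hand, a 6.3-fold lower number from compound 1 to compound 2 (0.80 log units; beyond the scatter), replaces the whole chain on that nitrogen rather than enlarging one part of it, so it bears only loosely. For compound 3 the number in this assay is therefore expected close to that of compound 2, a 1.3-fold higher number from compound 2 to compound 3 (0.12 log units; within the scatter), with a wide range: the estimate is 25 nM, between 8 nM and 80 nM.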

Compound 3, half-maximal inhibitory concentration: 25 nM
Compound 3: the middle estimate sits on the measured number at the digits printed; the measured number falls inside the stated range.
By their numbers in this assay, from the lowest: compounds 2 and 3 (each within the scatter of the next); then compound 1.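

In this assay, isopropyl in place of methyl on a saturated chain carbon bound to an aromatic carbon and an aromatic nitrogen gives a 1.3-fold higher number from compound 2 to compound 3 (0.12 log units; within the scatter) and so leaves the number at this position unresolved from that of the methyl compound. The 2-methyl-1-phenylpropyl group, like 1-phenylethyl, stands apart from heptyl, with a 4.8-fold lower number from compound 1 to compound 3 (0.68 log units; beyond the scatter) on the same nitrogen. No supporting data bear on this result. As far as these compounds go, whether tert-butyl or cyclohexyl on that carbon would hold this level remains open. So does the effect of an amine or a hydroxymethyl group there.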